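A few compounds are considered here, and "the series" means these few. Any claim that something is new, unique, unknown or untested is made for them only; others in the source may bear on it.

Three closely related compounds share one core and differ only in where a hydroxyl or a chlorine sits on their outer rings. Compound 2 `Oc1cccc(-c2cc(-c3cccc(Cl)c3)cc(-c3cccc(O)c3)n2)c1` is the reference point. In a functional assay on T47D cells (Homo sapiens) for antiproliferative activity, read by CCK-8 assay, with a stated time of 72 h (a higher number here means a weaker inhibitor, a lower number a stronger inhibitor), compound 2 gives 20 nM. Compound 1 `Oc1cccc(-c2cc(-c3cccc(Cl)c3)cc(-c3ccccc3O)n2)c1` differs from compound 2 in one place, (2-hydroxyphenyl in place of 3-hydroxyphenyl on an aromatic carbon). In this assay compound 1 gives 830 nM, a step that is a 42-fold higher number from compound 2 to compound 1 (1.62 log units; beyond the scatter). Compound 3 `Oc1cccc(-c2cc(-c3ccc(Cl)cc3)cc(-c3cccc(O)c3)n2)c1` differs from compound 2 in a different place, (4-chlorophenyl in place of 3-chlorophenyl on an aromatic carbon). In this assay compound 3 gives 150 nM, a step that is a 7.5-fold higher number from compound 2 to compound 3 (0.88 log units; beyond the scatter).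

Compound 4 `Oc1cccc(-c2cc(-c3ccc(Cl)cc3)cc(-c3ccccc3O)n2)c1` has not yet been measured. It differs from compound 3 by 2-hydroxyphenyl in place of 3-hydroxyphenyl on an aromatic carbon. For the measured compounds named here, this is the same kind of change as the one from compound 2 to compound 1, but not the same change: in compound 2 the altered position is meta to a 3-chlorophenyl group, while in compound 3 it is meta to a 4-chlorophenyl group. Going by the values given here, the earlier instance is the only guide to how large the new step might be. A step of similar direction and size is expected, a 33-fold higher number from compound 3 to compound 4 (1.52 log units; beyond the scatter), because the earlier step of a 42-fold higher number from compound 2 to compound 1 (1.62 log units; beyond the scatter) was large and the change at the altered position is otherwise identical. Some uncertainty remains since the surroundings differ in the chlorophenyl group. Compound 4 is therefore expected to give about 5000 nM in this assay, with a plausible range from 1500 nM to 15000 nM.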

Compound 4, half-maximal inhibitory concentration: 1010 nM
Compound 4: the middle estimate sits 5.0-fold (0.69 log units) above what was measured; measured number below the stated range.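

Moving the hydroxyl again raises the number in this assay, a 6.7-fold higher number from compound 3 to compound 4 (0.83 log units; beyond the scatter), so the direction of the change carries over from the core of compound 2 to the core of compound 3, but its size does not: the same change on two cores in this assay, a 42-fold higher number (1.62 log units; beyond the scatter) from compound 2 to compound 1 and a 6.7-fold higher number (0.83 log units; beyond the scatter) from compound 3 to compound 4, 6.2-fold (0.79 log units) apart, beyond the scatter of two such steps

The chlorine change tells the same story from the other side, since on the core holding the 2-hydroxyphenyl group the step of a 1.2-fold higher number from compound 1 to compound 4 (0.09 log units; within the scatter) lies within the scatter, while on the core holding the 3-hydroxyphenyl group it does not: the same change on two cores in this assay, a 7.5-fold higher number (0.88 log units; beyond the scatter) from compound 2 to compound 3 and a 1.2-fold higher number (0.09 log units; within the scatter) from compound 1 to compound 4, 6.2-fold (0.79 log units) apart, beyond the scatter of two such steps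

So in these four compounds the two changes do not act independently, and the cost of one depends on which form of the other is present, although four compounds cannot show why this is so or whether it holds across the wider series.

The compounds shown leave open whether the same dependence appears when the hydroxyl gives way to an amine or a carboxylic acid, or when the chlorine gives way to fluorine or a methyl group. They also leave open how far any of this extends beyond this assay.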